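From propyl to ethoxy at the limit of the assay

The source may report more compounds than this note shows. Statements on the series, on what has been measured and on what is new or still open speak of the compounds shown alone.

Measured in a functional assay on L1210 cells (Mus musculus) for inhibition, read by thymidine incorporation, with a stated time of 3 h (a lower number here means that less compound is needed, a higher number that more compound is needed for the effect), so far:
Compound 1 `CCCCCCCCCCCCCCCC(=O)NCC(=O)N[C@@H]1[C@@H](O)[C@H](O)[C@@H](Nc2ncnc3[nH]cnc23)O[C@H]1CO` gives 2.5 uM as a measured number.
Compound 2 `CCCCCC(=O)NCC(=O)N[C@@H]1[C@@H](O)[C@H](O)[C@@H](Nc2ncnc3[nH]cnc23)O[C@H]1C` gives > 1000 uM as a limit of the assay.

Of the two results, one rests on the limit of > 1000 uM in this assay, at which 1 of the 2 values shown sits, and so gives no exact number. Compound 2 therefore stands at > 1000 uM as a limit and not as a measured number.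

Compound 3 `CCOCCC(=O)NCC(=O)N[C@@H]1[C@@H](O)[C@H](O)[C@@H](Nc2ncnc3[nH]cnc23)O[C@H]1C` has not yet been measured. The change ethoxy in place of propyl on a saturated chain carbon, two bonds along the chain from a carbonyl carbon separates it from compound 2, with ethoxy in place of propyl on a saturated chain carbon, two bonds along the chain from a carbonyl carbon.

Among the compounds with values here, no measured step bears directly on this exchange, so the expectation rests on compound 2 alone. Compound 3 is expected to stay close to the limit that compound 2 shows at > 1000 uM in this assay with no shift beyond the usual scatter in either direction. The assay may well report only a limit again. The expected outcome is a number no higher from compound 2 to compound 3 (the limit leaves the size open) and no real change. The estimated value for compound 3 is 1000 uM with an expected range from 400 uM to 2500 uM for a numerical reading.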

Compound 3, concentration for half-maximal effect: > 1000 uM
Compound 3 ended at the assay's limit (the forecaster's own chance of this, stated with the estimate: 85%); the middle value lies on the limit itself.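

No step from compound 2 to compound 3 can be read, as both compounds rest on the same limit and neither gives an exact number: the limit of > 1000 uM in this assay, at which 2 of the 3 values shown sit.

The compounds shown leave open whether ethoxy in place of propyl on a saturated chain carbon, two bonds along the chain from a carbonyl carbon, changes the effect at all.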